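A Fluorophenyl Triazole Ester on a Shared Terpenoid Core

A few compounds are considered here, and "the series" means these few. Any claim that something is new, unique, unknown or untested is made for them only; others in the source may bear on it.

Three esters that share one core have been tested in an ADME assay on L132 cells (Homo sapiens) for cytotoxicity, read by MTT assay, with a stated time of 48 h; on this read-out higher numbers stand for weaker inhibition and lower numbers for stronger inhibition. Compound 1 `C/C(=C\CC/C(C)=C/CC[C@@H]1[C@@]2(C)CCC(=O)C(C)(C)[C@H]2CC[C@@]1(C)O)CC/C=C(\C)C(=O)OCc1cn(-c2ccccc2C(F)(F)F)nn1` gives > 150000 nM, which is a limit of the assay and not a number. Compound 2 `C/C(=C\CC/C(C)=C/CC[C@@H]1[C@@]2(C)CCC(=O)C(C)(C)[C@H]2CC[C@@]1(C)O)CC/C=C(\C)C(=O)OCc1cn(C[C@@H]2O[C@H](n3ccc(=O)[nH]c3=O)[C@H]3OC(C)(C)O[C@H]32)nn1` likewise gives > 150000 nM, again a limit. Compound 3 `C/C(=C\CC/C(C)=C/CC[C@@H]1[C@@]2(C)CCC(=O)C(C)(C)[C@H]2CC[C@@]1(C)O)CC/C=C(\C)C(=O)OCc1cn(-c2ccc([N+](=O)[O-])cc2)nn1` gives > 150000 nM, also a limit. All three values thus sit at the limit of > 150000 nM in this assay, at which 3 of the 3 values shown sit, and compound 3 stands at the same limit as the other two, with no number of its own. For the measured compounds named here, the only step between compounds that differ in one place, a step that the two limits leave unreadable from compound 1 to compound 3, cannot be read, both of its ends being limits.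

Compound 4 `C/C(=C\CC/C(C)=C/CC[C@@H]1[C@@]2(C)CCC(=O)C(C)(C)[C@H]2CC[C@@]1(C)O)CC/C=C(\C)C(=O)OCc1cn(-c2ccccc2F)nn1` differs from compound 3 by 2-fluorophenyl in place of 4-nitrophenyl on an aromatic nitrogen. Going by the values given here, the one measured step that bears on it, 4-nitrophenyl in place of 2-(trifluoromethyl)phenyl on an aromatic nitrogen, gave no readable size, so no size of step can be taken from it; the three limits are all the data offer. Every compound shown reached the limit whatever group stood on that aromatic nitrogen. The step of a number no higher from compound 3 to compound 4 (the limit leaves the size open) is therefore expected to be none beyond the scatter. Compound 4 is expected most likely to return a limit as well. The estimate for compound 4 is 150000 nM, ranging from 80000 nM to 300000 nM.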

Compound 4, half-maximal inhibitory concentration: > 150000 nM
Compound 4 was reported as a limit; the forecaster's own chance of this, stated with the estimate: 85%; the middle value sits exactly at the limit.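

In this assay compound 4 gives > 150000 nM, which is a limit of the assay and not a number. No new step can be read, as the comparisons of compound 4 with compound 3 and with compound 1 have limits at both ends. The compounds shown leave open how these esters compare with one another, none having a number of its own: the limit of > 150000 nM in this assay, at which 4 of the 4 values shown sit.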